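A few compounds are considered here, and "the series" means these few. Any claim that something is new, unique, unknown or untested is made for them only; others in the source may bear on it.

Compound 2 `Cc1cc(C)c(CN2CCc3c(Cl)cc([C@H](CO)[C@H]4CCOC4)c(Cl)c3C2=O)c(=O)[nH]1` gives 2.9 10^-6 cm/s in an ADME assay on MDCK cells (Canis lupus familiaris) for permeability, read by LC-MS, with a stated time of 90 min, tested at 2 uM (a higher number here means that the compound crosses the layer faster, a lower number that the compound crosses the layer more slowly), the lowest of the two single numbers shown. Compound 1 `Cc1cc(C)c(CN2CCc3c(Cl)cc([C@@H](CO)[C@H]4CCCO4)c(Cl)c3C2=O)c(=O)[nH]1` gives 8.5 10^-6 cm/s in this assay, and compound 3 `Cc1cc(C)c(CN2CCc3c(Cl)cc(C(CO)C4CCOC4)c(Cl)c3C2=O)c(=O)[nH]1` gives 2.5 10^-6 cm/s; 2.7 10^-6 cm/s (2 entries), its repeats agreeing closely, as the several entries of compound 3 in this assay, 2.5 10^-6 cm/s; 2.7 10^-6 cm/s (2 entries) shows; compound 3 and compound 2 lie close to each other even given (the fact that one of compounds 2 and 3 is drawn with a defined configuration and the other without, at the place where they differ). Compound 4 `Cc1cc(C)c(CN2CCc3c(Cl)cc([C@H](C)CO)c(Cl)c3C2=O)c(=O)[nH]1` differs from compound 2 in one place: a group of 4 heavy atoms (3 carbon, 1 oxygen; no ring) in place of a group of 8 heavy atoms (6 carbon, 2 oxygen; one five-membered non-aromatic ring with 1 hetero atom), on an aromatic carbon. For the measured compounds named here, the only measured step at this place is a 2.9-fold lower number from compound 1 to compound 2 (0.47 log units; beyond the scatter), a swap of one five-membered non-aromatic ring with 1 hetero atom for another of the same size, whereas here the ring leaves entirely, so that step is a loose guide at best. For compound 4 the number in this assay is expected to be 4 10^-6 cm/s, between 1.5 10^-6 cm/s and 11 10^-6 cm/s. That corresponds to an expected step of a 1.4-fold higher number from compound 2 to compound 4 (0.14 log units; within the scatter).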

Compound 4, apparent permeability: 12.4 10^-6 cm/s
Compound 4: middle estimate off by 3.1-fold (0.49 log units), on the low side; the measured number lies above the stated range.
By their numbers in this assay, from the lowest: compound 2; then compounds 1 and 4 (each within the scatter of the next).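

In this assay, losing the ring has no single outcome: the change to the smaller 1-(hydroxymethyl)ethyl group gives a 4.3-fold higher number from compound 2 to compound 4 (0.63 log units; beyond the scatter) when the ring of compound 2 leaves, but a 1.5-fold higher number from compound 1 to compound 4 (0.16 log units; within the scatter) when oxolan-2-yl gives way to methyl. At this position, then, the result of removing the ring depends on which ring-bearing group it is compared with. Nothing shown here explains why the two comparisons differ. Still open, on these data alone, is how a longer chain in place of the methyl of compound 4 would behave, or an amine or a carboxylic acid in place of its hydroxyl.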